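From a Halogenated Phenyl to Pyridin-3-yl: An Expected Step

A few compounds are considered here, and "the series" means these few. Any claim that something is new, unique, unknown or untested is made for them only; others in the source may bear on it.

Compound 1 `Cc1ccc(-c2c(C)nn(-c3nc(-c4ccc(Cl)c(Cl)c4)c(SC(C)C)s3)c2C(=O)O)cc1`: 3800 nM
Compound 2 `Cc1c(-c2cc(Cl)cc(Cl)c2)c(C(=O)O)nn1-c1nc(-c2ccc3nccn3c2)c(SC(C)C)s1`: "not active" (no number reported)
Compound 3 `Cc1c(-c2cc(Cl)cc(Cl)c2)c(C(=O)O)nn1-c1nc(-c2cc(Cl)ccc2F)c(SC(C)C)s1`: 4800 nM

In a functional assay on BJAB cells (Homo sapiens) for antiproliferative activity, with a stated time of 4 days (on this read-out lower numbers stand for an effect already at smaller amounts and higher numbers for an effect only at larger amounts of compound), compound 3 gives 4800 nM, the higher of the two numbers reported. The nearest number belongs to compound 1, which gives 3800 nM, a gap within the scatter, so the two cannot be ordered. Compound 2 gives "not active" (no number reported), without a number.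

Compound 4 `Cc1c(-c2cc(Cl)cc(Cl)c2)c(C(=O)O)nn1-c1nc(-c2cccnc2)c(SC(C)C)s1` differs from compound 3 by pyridin-3-yl in place of 5-chloro-2-fluorophenyl on an aromatic carbon. Going by the values given here, no measured pair shows this change, so the step is uncertain. Compound 4 is expected to show a 1.9-fold higher number from compound 3 to compound 4 (0.27 log units; within the scatter), a step toward higher numbers beyond the scatter. That expectation leans on compound 2, which in this assay gives "not active" (no number reported). The estimate for compound 4 is 9000 nM, with a range from 3000 nM to 30000 nM.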

Compound 4, half-maximal effective concentration: "not active" (no number reported)
Compound 4: no number reported; there is nothing to compare the estimate with.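

In this assay, going by these compounds alone, compound 4 gives "not active" (no number reported) and so no step from compound 3 can be read. Nothing shown explains this result.
The compounds shown leave open how pyridin-3-yl in place of 5-chloro-2-fluorophenyl changes the number.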